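A few compounds are considered here, and "the series" means these few. Any claim that something is new, unique, unknown or untested is made for them only; others in the source may bear on it.

Of the compounds shown here, three built on one shared core have been measured in a functional assay (Pituitary gland cell) with Rattus norvegicus as the target; a higher number here means that more compound is needed for the effect, a lower number that less compound is needed. Compound 1 `CC(C)(N)CC(=O)N[C@@H]1CCc2ccccc2N(Cc2ccc(-c3ccccc3-c3nnnn3CC(=O)O)cc2)C1=O` gives 1 uM, compound 2 `CC(C)(N)CC(=O)N[C@@H]1CCc2ccccc2N(Cc2ccc(-c3ccccc3C(N)=O)cc2)C1=O` gives 0.08 uM, and compound 3 `CC(C)(N)CC(=O)N[C@@H]1CCc2ccccc2N(Cc2ccc(-c3ccccc3-c3nnnn3Cc3ccccc3)cc2)C1=O` gives 0.7 uM. Compound 3 thus stands second highest of the three, close to compound 1 and far from compound 2. Compound 4 `CC(C)(N)CC(=O)N[C@@H]1CCc2ccccc2N(Cc2ccc(-c3ccccc3C#N)cc2)C1=O` is not yet measured; it differs from compound 3 by cyano in place of 1-benzyl-1H-tetrazol-5-yl on an aromatic carbon. The step that bears most on this change is an 8.8-fold higher number from compound 2 to compound 3 (0.94 log units; beyond the scatter), where the smaller carbamoyl sat on the same aromatic carbon; a 13-fold lower number from compound 1 to compound 2 (1.10 log units; beyond the scatter) points the same way. Because of an 8.8-fold higher number from compound 2 to compound 3 (0.94 log units; beyond the scatter) compound 4 is expected to give a lower number, a 3.5-fold lower number from compound 3 to compound 4 (0.54 log units; beyond the scatter), though not as low as compound 2. The estimate for compound 4 is 0.2 uM, within 0.05 uM to 0.8 uM.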

Compound 4, concentration for half-maximal effect: 5 uM
Estimate against measurement, compound 4: 25-fold (1.40 log units) below; measured number above the stated range.
By their numbers in this assay, from the lowest: compound 2; then compounds 3 and 1 (each within the scatter of the next); then compound 4.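

At this aromatic carbon, a smaller group does not by itself lower the number: a 7.1-fold higher number from compound 3 to compound 4 (0.85 log units; beyond the scatter) comes with cyano in place of 1-benzyl-1H-tetrazol-5-yl. Cyano also stands apart from the other groups, with a 63-fold higher number from compound 2 to compound 4 (1.80 log units; beyond the scatter) against carbamoyl, the largest step in the set, and a 5.0-fold higher number from compound 1 to compound 4 (0.70 log units; beyond the scatter) against 1-(carboxymethyl)-1H-tetrazol-5-yl. Nothing shown here explains why these groups differ. As far as these compounds go, whether a carboxylic acid or an amine placed directly on this aromatic carbon would fall nearer carbamoyl or cyano remains open.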